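This account rests on a few compounds, and the source may have more. Where it says the series, first, only, none or still open, it means among the compounds named here.

In a functional assay on A-375 cells (Homo sapiens) for cytotoxicity, read by MTT assay, with a stated time of 72 h (on this read-out higher numbers stand for weaker inhibition and lower numbers for stronger inhibition), compound 1 `CN(C)CCCCCn1c2c(c3ccccc31)C(=O)c1c[n+]([O-])c3ccccc3c1C2=O` gives 560 nM and compound 2 `CN(C)CCCCn1c2c(c3ccccc31)C(=O)c1c[n+]([O-])c3ccccc3c1C2=O` gives 470 nM. Among the measured compounds shown here, compound 2 thus stands level with compound 1, its only neighbour on these numbers: a 1.2-fold lower number from compound 1 to compound 2 (0.08 log units; within the scatter). Compound 3 `O=C1c2c[n+]([O-])c3ccccc3c2C(=O)c2[nH]c3ccccc3c21` is compound 2 with hydrogen in place of 4-(dimethylamino)butyl on an aromatic nitrogen. For the measured compounds named here, the single measured step bears on this change only weakly. Going by the values given here, that step shortens the chain and keeps the dimethylamino end, and no measured compound lacks the chain altogether. It therefore sets no size for the new step, and a change well beyond it is possible. In this assay, a move towards a higher number is expected, though the direction remains uncertain. What is estimated is a 3.2-fold higher number from compound 2 to compound 3 (0.50 log units; beyond the scatter). For compound 3 the expected value is 1500 nM, with an estimated range from 300 nM to 8000 nM.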

Compound 3, half-maximal inhibitory concentration: 660 nM
For compound 3 the middle estimate is 2.3-fold (0.36 log units) above the measured one, and the stated range covers the measured number.
By their numbers in this assay, from the lowest: compounds 2, 1 and 3 (each within the scatter of the next).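

In this assay compound 3, with hydrogen on the aromatic nitrogen, stands level with both chain-bearing compounds: a 1.4-fold higher number from compound 2 to compound 3 (0.15 log units; within the scatter) in place of 4-(dimethylamino)butyl and a 1.2-fold higher number from compound 1 to compound 3 (0.07 log units; within the scatter) in place of 5-(dimethylamino)pentyl. The earlier step compared only two chains ending in dimethylamino, whereas these steps show that on this nitrogen the whole chain can be absent and the number still lies within the scatter of both chain-bearing compounds. No measured property is available to explain this result.

As far as these compounds go, what a short group such as methyl would give on this nitrogen remains open. So does the outcome for a chain ending in a carboxylic acid, a primary amine or a morpholine ring.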